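Shortening the Side Chain on the Shared Core

A few compounds are considered here, and "the series" means these few. Any claim that something is new, unique, unknown or untested is made for them only; others in the source may bear on it.

Compound 1 `CN1CCN(CCCCCCn2c3c(c4ccccc42)C(=O)c2c[n+]([O-])c4ccccc4c2C3=O)CC1` carries a long chain ending in a methylpiperazine on the shared core. In a functional assay on A-375 cells (Homo sapiens) for cytotoxicity, read by MTT assay, with a stated time of 72 h (a higher number here means a weaker inhibitor, a lower number a stronger inhibitor), compound 1 gives 630 nM, the top number among the three measured compounds, though each gap to the others lies inside the scatter. Compound 2 `CN(C)CCCCn1c2c(c3ccccc31)C(=O)c1c[n+]([O-])c3ccccc3c1C2=O` gives 470 nM in this assay, and compound 3 `O=C1c2c[n+]([O-])c3ccccc3c2C(=O)c2c1c1ccccc1n2CCN1CCCC1` gives 430 nM. The measured steps, a 1.3-fold lower number from compound 1 to compound 2 (0.13 log units; within the scatter), a 1.5-fold lower number from compound 1 to compound 3 (0.17 log units; within the scatter) and a 1.1-fold lower number from compound 2 to compound 3 (0.04 log units; within the scatter), all swap the amine and the chain length together and all stay within the scatter.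

Compound 4 `CN1CCN(CCCn2c3c(c4ccccc42)C(=O)c2c[n+]([O-])c4ccccc4c2C3=O)CC1` keeps the methylpiperazine but shortens the chain: 4-methylpiperazin-1-yl in place of 3-(4-methylpiperazin-1-yl)propyl on a saturated chain carbon, three bonds along the chain from an aromatic nitrogen. Within the data shown here, no measured step changes chain length alone, yet the three steps that alter it together with the amine show nothing beyond the scatter, so the expected step in this assay is small, a 1.2-fold lower number from compound 1 to compound 4 (0.08 log units; within the scatter). Compound 4 is therefore estimated at 520 nM in this assay, within a range from 250 nM to 1100 nM.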

Compound 4, half-maximal inhibitory concentration: 470 nM
Beside the measured number, compound 4's estimate is 1.1-fold (0.04 log units) above it; the measured number falls inside the stated range.
By their numbers in this assay, from the lowest: compounds 3, 2, 4 and 1 (each within the scatter of the next).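

Among these compounds, compound 4 gives the only step here in which the methylpiperazine stays and the chain alone shortens, and in this assay that step, a 1.3-fold lower number from compound 1 to compound 4 (0.13 log units; within the scatter), stays within the scatter. The steps that also change the amine, a 1.1-fold higher number from compound 3 to compound 4 (0.04 log units; within the scatter) and no change at the digits printed from compound 2 to compound 4 (within the scatter), stay within it too, so at this position neither chain length nor amine separates these four compounds in this measurement. Nothing shown here gives a reason for this sameness.

Still open, on these data alone, is whether a morpholine or a carboxylic acid in place of the methylpiperazine would move the number beyond the scatter. Among the compounds shown here, equally open is whether a chain longer than the one in compound 1 would do so.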